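This account rests on a few compounds, and the source may have more. Where it says the series, first, only, none or still open, it means among the compounds named here.

Among the compounds with values here, in a functional assay with Homo sapiens as the target (a lower number here means a stronger inhibitor, a higher number a weaker inhibitor), compound 1 (`CC(C)[C@H](NC(=O)COc1cccc2ccccc12)C(=O)N[C@@H](CC(=O)O)C(=O)COc1ccccc1`) gives 11200 nM, and compound 2 (`CC(C)[C@H](NC(=O)COc1cccc2ccccc12)C(=O)N[C@@H](CC(=O)O)C(=O)COc1ccccc1[N+](=O)[O-]`) gives 27700 nM, the highest of the two numbers so far. Compound 3 (`CC(C)[C@H](NC(=O)COc1cccc2ccccc12)C(=O)N[C@@H](CC(=O)O)C(=O)COc1ccccc1F`) has not yet been measured. It departs from compound 2 at a single substituent: fluoro in place of nitro on an aromatic carbon. Put simply, fluoro takes the place of nitro on an aromatic carbon, ortho to a large group. Within the data shown here, only one measured step bears on this change: a 2.5-fold higher number from compound 1 to compound 2 (0.39 log units; beyond the scatter), a modest step that came with nitro in place of hydrogen. Among the measured compounds shown here, no fluoro compound has been measured, so that step gives only an indirect guide. With the nitro gone, the number is expected to return towards that of compound 1 at 11200 nM. The expected change is therefore modest and downward in this assay, an estimated 2.3-fold lower number from compound 2 to compound 3 (0.36 log units; beyond the scatter). The estimate for compound 3 is 12000 nM, with an expected range of 5000 nM to 28000 nM.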

Compound 3, half-maximal inhibitory concentration: 15700 nM
For compound 3 the middle estimate is 1.3-fold (0.12 log units) below the measured one; the range from low to high includes it.
By their numbers in this assay, from the lowest: compounds 1, 3 and 2 (each within the scatter of the next, the first and the last beyond it).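

In this assay the place on the aromatic carbon ortho to a large group now carries a third substituent, and fluoro reads within the scatter of both other compounds: replacing nitro gives a 1.8-fold lower number from compound 2 to compound 3 (0.25 log units; within the scatter) and replacing hydrogen gives a 1.4-fold higher number from compound 1 to compound 3 (0.15 log units; within the scatter). Within the data shown here, of the three steps at this position, only the one that introduces nitro, a 2.5-fold higher number from compound 1 to compound 2 (0.39 log units; beyond the scatter), lies beyond the scatter, so compound 3 cannot be told apart from either compound 1 or compound 2. Nothing given here explains these numbers.

The compounds shown leave open how a chloro group, a methoxy group or an amine would read at this same place. They also leave open whether fluoro and nitro would give similar steps on a core other than the shared one.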